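The source may report more compounds than this note shows. Statements on the series, on what has been measured and on what is new or still open speak of the compounds shown alone.

Series notes, urea-linked analogues on a shared pyrazole core, read in a functional assay on KM12 cells (Homo sapiens) for inhibition, read by sulforhodamine B assay, with a stated time of 48 h, tested at 100 uM; a higher number here means a weaker effect of the compound at the concentration tested, a lower number a stronger effect:

- compound 1 `O=C(Nc1cccc(-n2cc(-c3ccncc3)c(-c3cc(O)cc(Cl)c3)n2)c1)Nc1ccc(Cl)c(C(F)(F)F)c1` gives -74%
- compound 2 `O=C(Nc1cccc(-n2cc(-c3ccncc3)c(-c3cc(O)cc(Cl)c3)n2)c1)Nc1ccc(Cl)c(Cl)c1` gives -63%
- compound 3 `COc1cc(Cl)cc(-c2nn(-c3cccc(NC(=O)Nc4cc(C(F)(F)F)cc(C(F)(F)F)c4)c3)cc2-c2ccncc2)c1` gives -83%

Compound 3 holds the lowest of the three numbers; its gap to compound 1 lies within the scatter, its gap to compound 2 beyond it, so compound 3 and compound 1 cannot be ranked against each other on these data.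

Compound 4 `COc1cc(Cl)cc(-c2nn(-c3cccc(NC(=O)Nc4cccc(C(F)(F)F)c4)c3)cc2-c2ccncc2)c1` is not yet measured. It differs from compound 3 in one place: hydrogen in place of trifluoromethyl on an aromatic carbon. The other trifluoromethyl group on that ring stays.

Going by the values given here, only one measured step touches the same ring: a number 11 percentage points higher from compound 1 to compound 2 (beyond the scatter), a change at a trifluoromethyl on the terminal aryl of the urea. That step was modest and went toward a weaker effect. Removing a trifluoromethyl altogether, rather than swapping it for chloro, is a somewhat larger change, and the same direction is expected. A step of roughly that size or a little more is expected in this assay, toward a higher number, with the outcome still well on the active side.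

Compound 4 is therefore expected to give -68%, within -85% to -48%, the expected step being a number 15 percentage points higher from compound 3 to compound 4 (beyond the scatter).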

Compound 4, a percentage reported as activity, at one concentration (the size of the read-out at that concentration, not a potency): -48%
Beside the measured number, compound 4's estimate is 20 percentage points below it; the range from low to high includes it.
By their numbers in this assay, from the lowest: compounds 3 and 1 (each within the scatter of the next); then compound 2; then compound 4.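

In this assay, going by these compounds alone, the step of a number 35 percentage points higher from compound 3 to compound 4 (beyond the scatter) is the first measured loss of a trifluoromethyl without any replacement, on an aromatic carbon of a six-membered aromatic ring of carbon only, and it shows that this position weighs heavily on the read-out. The change is larger than a number 11 percentage points higher from compound 1 to compound 2 (beyond the scatter) at a trifluoromethyl on the same terminal ring, although the two steps stand on different backgrounds and sit at differently substituted rings, so the comparison shows only that both go toward a weaker effect, not how much of the difference belongs to the replacing atom. Within the data shown here, the one remaining trifluoromethyl in compound 4 does not keep the number close to that of compound 3, and nothing at hand explains why this step is so large.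

Open, on these data alone, is whether a chloro, a methyl or an amine on this carbon of compound 3 would restore part of the effect or leave the number near that of compound 4. Also open, as far as these compounds go, is whether the same removal on the hydroxy-bearing background of compound 1 gives a step of similar size, and all of these readings come from a single concentration, which says nothing of potency.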